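Moving the Bromine Around the Anilino Ring

The source may report more compounds than this note shows. Statements on the series, on what has been measured and on what is new or still open speak of the compounds shown alone.

Compound 1 `Fc1cccc(-c2nc(Nc3ccc(Br)cc3)c3cc(F)ccc3n2)c1` and compound 2 `Fc1cccc(-c2nc(Nc3cccc(Br)c3)c3cc(F)ccc3n2)c1` share one core and differ only in where the bromine sits on the phenyl ring attached to the nitrogen. In a functional assay on HT29-AK cells (Homo sapiens) for cytotoxicity, read by MTT assay, with a stated time of 48 h (on this read-out lower numbers stand for stronger inhibition and higher numbers for weaker inhibition), compound 1 reaches only the assay limit of > 50000 nM. Compound 2 likewise gives only the limit > 50000 nM in this assay. The step that the two limits leave unreadable from compound 1 to compound 2 therefore cannot be sized, since both values sit at the limit of > 50000 nM in this assay, at which 2 of the 2 values shown sit. Compound 3 `Fc1cccc(-c2nc(Nc3ccccc3Br)c3cc(F)ccc3n2)c1` carries the change (2-bromophenyl in place of 3-bromophenyl on a nitrogen on an aromatic ring). With no readable step to draw on, no shift beyond the scatter is expected. Compound 3 is therefore expected at 60000 nM in this assay, most likely once more as a limit. That expectation amounts to an estimated step that the limit leaves unreadable from compound 2 to compound 3.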

Compound 3, half-maximal inhibitory concentration: > 50000 nM
Compound 3: a limit, no number; the forecaster's own chance of this, stated with the estimate: 85%; the middle value does not contradict the limit.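

No step can be read among compound 1, compound 2 and compound 3, since each value is only a limit: the limit of > 50000 nM in this assay, at which 3 of the 3 values shown sit. As far as these compounds go, whether moving the bromine around the ring changes the true potency therefore stays open.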